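The source may report more compounds than this note shows. Statements on the series, on what has been measured and on what is new or still open speak of the compounds shown alone.

In a functional assay on U-937 cells (Homo sapiens) for antiproliferative activity, read by MTT assay, with a stated time of 24 h (on this read-out lower numbers stand for stronger inhibition and higher numbers for weaker inhibition), compound 1 `CCCCc1oc2ccccc2c1C(=O)c1ccc(OCC(=O)Nc2cccc(OC)c2)cc1` gives 24200 nM and compound 2 `CCCCc1oc2ccccc2c1C(=O)c1cc(I)c(OCCCN2CCCCC2)c(I)c1` gives 18200 nM. Compound 3 `CCCCc1oc2ccccc2c1C(=O)c1cc(I)c(OCCCN2CCN(C)CC2)c(I)c1` reads > 50000 nM, which is a limit and not a number. Compound 4 `CCCCc1oc2ccccc2c1C(=O)c1cc(I)c(OCCCN2CCN(Cc3ccccc3)CC2)c(I)c1` differs from compound 3 by phenyl in place of hydrogen on a saturated chain carbon bound to an amine nitrogen in a ring, that is, methyl to benzyl. Going by the values given here, no measured step covers this change. The nearest is an at least 2.7-fold higher number from compound 2 to compound 3 (0.43 log units; beyond the scatter), on the same side chain. From the compounds shown here alone, compound 3 stands at the limit of > 50000 nM in this assay, at which 1 of the 3 values shown sits, so the size of any change in this assay stays open, and only a modest move to a lower number is expected. The expected change is an at least 1.4-fold lower number from compound 3 to compound 4 (0.15 log units; that floor lies within the scatter). Compound 4 is estimated at 35000 nM, with an expected range of 15000 nM to 70000 nM.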

Compound 4, half-maximal inhibitory concentration: 41400 nM
Beside the measured number, compound 4's estimate is 1.2-fold (0.07 log units) below it; the measured number falls inside the stated range.
By their numbers in this assay, from the lowest: compounds 2, 1 and 4 (each within the scatter of the next, the first and the last beyond it). At a limit, above all of these: compound 3.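

Phenyl in place of hydrogen on a saturated chain carbon bound to an amine nitrogen in a ring, that is, methyl to benzyl, gives an at least 1.2-fold lower number from compound 3 to compound 4 (0.08 log units; that floor lies within the scatter). In this assay, compound 3 reads > 50000 nM, which is a limit and not a number. Only the floor of this step can therefore be read, and its true size stays open: the limit of > 50000 nM in this assay, at which 1 of the 4 values shown sits.

From the compounds shown here alone, whether a longer chain, as in phenethyl, would shift the reading remains open. So does the effect of replacing benzyl with a pyridylmethyl or an acetyl group on that nitrogen.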